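One Methyl Group, Tried on Two Related Cores

A few compounds are considered here, and "the series" means these few. Any claim that something is new, unique, unknown or untested is made for them only; others in the source may bear on it.

Compound 1 `COC(=O)N(C)CC#CCN(C)C` and compound 2 `COC(=O)N(C)C(C)C#CCN(C)C` share a core and differ in a single change, (methyl in place of hydrogen on a saturated chain carbon bound to an amide-type nitrogen and a triple-bonded carbon). In a functional assay on the whole organism for agonist activity, with Mus musculus as the target (a higher number here means that more compound is needed for the effect, a lower number that less compound is needed), compound 1 gives 9.7 mg/kg, and compound 2 gives 17.3 mg/kg. That change made a step of a 1.8-fold higher number from compound 1 to compound 2 (0.25 log units; within the scatter). Compound 3 `CCOC(=O)N(C)CC#CCN1CCCC1` is built on a different core, and the difference between the two cores is not broken down here. In this assay compound 3 reached only a limit, > 100 mg/kg, the same limit noted as the limit of > 100 mg/kg in this assay, at which 1 of the 3 values shown sits. Compound 4 `CCOC(=O)N(C)C(C)C#CCN1CCCC1` differs from compound 3 by the same change, (methyl in place of hydrogen on a saturated chain carbon bound to an amide-type nitrogen and a triple-bonded carbon). Compound 4 is expected to take a step that the limit leaves unreadable from compound 3 to compound 4, which rests on the earlier step of a 1.8-fold higher number from compound 1 to compound 2 (0.25 log units; within the scatter) staying within the scatter. Compound 4 is therefore estimated at 150 mg/kg, most likely once more only a limit.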

Compound 4, dose for half-maximal effect: > 100 mg/kg
Compound 4: only a limit was reported; the forecaster's own chance of this, stated with the estimate: 80%; the middle value is on the limit's open side.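

Compound 3 and compound 4 both stop at a limit rather than a number, so no step can be read between them: the limit of > 100 mg/kg in this assay, at which 2 of the 4 values shown sit. Going by these compounds, whether methyl in place of hydrogen shifts the dose needed on this core stays open.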